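Swapping 4-chlorophenyl for 3-methoxyphenyl on the carbonyl

The compounds below may be only part of what the source reports. "The series", "measured", "known", "first", "only" and "open" are said of these compounds alone.

Compounds measured so far in a functional assay on HCT-116 cells (Homo sapiens) for antiproliferative activity, read by MTT assay, with a stated time of 72 h (a lower number here means a stronger inhibitor, a higher number a weaker inhibitor), are these:
- compound 1 `CN(C(=O)c1ccc(F)cc1)c1ccc2[nH]c(-c3n[nH]c4ccccc34)cc2n1` gives 9270 nM
- compound 2 `CN(C(=O)c1ccc(Cl)cc1)c1ccc2[nH]c(-c3n[nH]c4ccccc34)cc2n1` gives 3000 nM

Compound 2 holds the lower of the two numbers. Going on to compound 3 `COc1cccc(C(=O)N(C)c2ccc3[nH]c(-c4n[nH]c5ccccc45)cc3n2)c1` changes one group on a carbonyl carbon, with 3-methoxyphenyl in place of 4-chlorophenyl (3-methoxyphenyl in place of 4-chlorophenyl on a carbonyl carbon). Among the measured compounds shown here, the one measured step that bears on this is a 3.1-fold lower number from compound 1 to compound 2 (0.49 log units; beyond the scatter) and it shows that a single swap on the aromatic group can move the number modestly. For the measured compounds named here, no methoxy example has been measured, so a modest step toward a higher number is expected in this assay for this change. The expected size is a 1.7-fold higher number from compound 2 to compound 3 (0.22 log units; within the scatter) by this estimate. For compound 3 the estimated value is 5000 nM with an expected range of 1800 nM to 14000 nM in this measurement.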

Compound 3, half-maximal inhibitory concentration: 14200 nM
For compound 3 the middle estimate is 2.8-fold (0.45 log units) below the measured one; measured number above the stated range.
By their numbers in this assay, from the lowest: compound 2; then compounds 1 and 3 (each within the scatter of the next).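

In this assay, the 3-methoxyphenyl group does not keep the advantage seen with 4-chlorophenyl, giving a 4.7-fold higher number from compound 2 to compound 3 (0.68 log units; beyond the scatter). Against 4-fluorophenyl it gives a 1.5-fold higher number from compound 1 to compound 3 (0.19 log units; within the scatter), so among these three groups only 4-chlorophenyl stands apart. Nothing here accounts for this difference.

Because this swap changes both the substituent and its place on the ring, the two effects cannot be separated. On these data alone, whether 3-chlorophenyl or 4-methoxyphenyl would read like compound 2 or like compound 3 remains open, as does the effect of an amine on that ring.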